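Acid dissociation notes on the chain variants

The compounds below may be only part of what the source reports. "The series", "measured", "known", "first", "only" and "open" are said of these compounds alone.

Measured so far in a physicochemical assay for acid dissociation:
compound 1 `Brc1cccc(Br)c1N(CC1CC1)C1=NCCN1` gives 10.9
compound 2 `Brc1cccc(N(CC2CC2)C2=NCCN2)c1Br` gives 11.1
compound 3 `CCCN(C1=NCCN1)c1c(Br)cccc1Br` gives 11

Compound 3 sits in the middle of the three numbers. Its nearest neighbour is compound 1 with 10.9, within the scatter, and the furthest is compound 2 with 11.1, also within the scatter. Going by the values given here, the one measured step that touches the chain on the nitrogen, a number 0.10 log units higher from compound 1 to compound 3 (within the scatter), stays inside the scatter.

Compound 4 `CC(C)=CCN(C1=NCCN1)c1c(Br)cccc1Br` differs from compound 3 as follows: 2-methylprop-1-en-1-yl in place of ethyl on a saturated chain carbon bound to a nitrogen on an aromatic ring. Among the compounds with values here, no measured pair shows a double bond outside aromatic rings entering the chain, so the only guide is the step from compound 1 to compound 3, which was flat. Compound 4 is therefore expected to give about the same number as compound 3, with a step of no change at the digits printed from compound 3 to compound 4 (within the scatter), nothing beyond the scatter in either direction. The estimate for compound 4 in this assay is 11, in the range 10.6 to 11.4.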

Compound 4, acid dissociation constant: 10.8
For compound 4 the middle estimate is 0.20 log units above the measured one, and the stated range covers the measured number.
By their numbers in this assay, from the lowest: compounds 4, 1, 3 and 2 (each within the scatter of the next).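

In this assay the place on a saturated chain carbon bound to a nitrogen on an aromatic ring now holds a third group, and 2-methylprop-1-en-1-yl, with its 1 double bond outside aromatic rings, still gives a step within the scatter, a number 0.20 log units lower from compound 3 to compound 4 (within the scatter), and the comparison with cyclopropyl reads the same way, a number 0.10 log units lower from compound 1 to compound 4 (within the scatter). Across compound 1, compound 3 and compound 4, then, ethyl, cyclopropyl and the larger unsaturated group are not told apart at this place by this read-out. Nothing available explains these numbers or ties them to a property of the groups.

Going by these compounds, whether an amine, a carboxylic acid or a much longer chain at this place would give a step beyond the scatter stays open. The compounds shown hold no such step at this place, so how far the number can move here also stays open.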